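The source may report more compounds than this note shows. Statements on the series, on what has been measured and on what is new or still open speak of the compounds shown alone.

Measured in a functional assay on NCI-H630 cells (Homo sapiens) for cytotoxicity, read by sulforhodamine B assay, with a stated time of 5 days; a lower number here means a stronger inhibitor, a higher number a weaker inhibitor:
- compound 1 `O=C(CCCCCCCCCCc1ccccc1)N[C@H]1CCOC1=O`: 66000 nM
- compound 2 `O=C(CCCCCCCCCc1ccccc1)CC(=O)N[C@@H]1CCOC1=O`: > 100000 nM (a limit)
- compound 3 `O=C(CCCCCCCCCCCc1ccccc1)N[C@H]1CCOC1=O`: > 100000 nM (a limit)

Compound 3 has no numerical value, and its > 100000 nM is a limit of the assay. Compound 2 gives > 100000 nM, which is also a limit. Compound 3 therefore stands at the limit of > 100000 nM in this assay, at which 2 of the 3 values shown sit. Only compound 1 has a numerical value in this assay, at 66000 nM.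

Compound 4 `O=C(CCCCCCCCCc1ccccc1)N[C@H]1CCOC1=O` is not yet measured. Its difference from compound 3 is phenyl in place of phenethyl on a saturated chain carbon, nine bonds along the chain from a carbonyl carbon.

Among the compounds with values here, one measured step bears on this change: an at least 1.5-fold higher number from compound 1 to compound 3 (0.18 log units; that floor lies within the scatter). That step lengthens the chain, while the change to compound 4 shortens it, so the measured step points to a lower number in this assay. The support is weak, since the step is only a floor and that floor lies within the scatter. A modest move is therefore expected, and a result at the limit remains possible. The expected step is an at least 1.6-fold lower number from compound 3 to compound 4 (0.22 log units; that floor lies within the scatter). Compound 4 is estimated at 60000 nM, with an expected range from 25000 nM to 120000 nM.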

Compound 4, half-maximal inhibitory concentration: > 100000 nM
Compound 4: a limit, no number; the forecaster's own chance of this, stated with the estimate: 30%; at least 1.6-fold (0.22 log units) between middle value and limit.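

In this assay, the result for compound 4 is a limit, so the shorter chain, with phenyl in place of phenethyl on a saturated chain carbon, nine bonds along the chain from a carbonyl carbon, gives no readable number, just as the longer chain of compound 3 did not. Within the data shown here, the steps that join two limits cannot be read, and the one readable step is an at least 1.5-fold higher number from compound 1 to compound 4 (0.18 log units; that floor lies within the scatter), so compound 1 cannot be separated from compound 4 on these data, and the measured number of compound 1 does not establish a preferred chain length. The three chain lengths in this amide set therefore show no ordering, and the readings have largely collapsed onto a single ceiling: the limit of > 100000 nM in this assay, at which 3 of the 4 values shown sit.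

The compounds shown leave open whether any change at this position can produce a number clearly beyond the scatter, and how far compound 3 and compound 4 lie past their limits. As far as these compounds go, it also remains open how a much shorter chain, or an amine or a carboxylic acid in place of the phenyl, would read in this assay.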